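Extending the nitrooxy chain of compound 2

The source may hold more compounds than are shown below. What is called first, only, known or untested is meant among the compounds shown, and "the series" means these compounds.

In a functional assay on a cell-free system (Platelet, plasma, Oryctolagus cuniculus) for inhibition, read by turbidimetry, with a stated time of 5 min (on this read-out higher numbers stand for weaker inhibition and lower numbers for stronger inhibition), compound 1 (`CCCCC(OC(=O)CN1CCN(CCCCCCOc2ccc(-c3cc(=S)ss3)cc2)CC1)c1ccccc1C(=O)Oc1ccc(/C=C/C(=O)OCCO[N+](=O)[O-])cc1OC`) gives a half-maximal inhibitory concentration of 430000 nM and compound 2 (`CCCCC(OC(=O)CN1CCN(CCCCOc2ccc(-c3cc(=S)ss3)cc2)CC1)c1ccccc1C(=O)Oc1ccc(/C=C/C(=O)OCCCCO[N+](=O)[O-])cc1OC`) gives 360000 nM on the same read-out. These two figures lie within the scatter of each other, so compound 2 cannot be separated from compound 1. Compound 3 (`CCCCC(OC(=O)CN1CCN(CCCCOc2ccc(-c3cc(=S)ss3)cc2)CC1)c1ccccc1C(=O)Oc1ccc(/C=C/C(=O)OCCCCCCO[N+](=O)[O-])cc1OC`) carries 2-(nitrooxy)ethyl in place of nitrooxy on a saturated chain carbon, four bonds along the chain from an oxygen next to a carbonyl group. Going by the values given here, no measured pair isolates this change. Compound 1 and compound 2 differ in more than one place, yet their values stay within the scatter, so no step beyond the scatter is expected in this assay here. The estimated step is small (a 1.1-fold lower number from compound 2 to compound 3 (0.02 log units; within the scatter)) and has no firm direction. The expected value for compound 3 is 340000 nM (estimated range 170000 nM to 650000 nM).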

Compound 3, half-maximal inhibitory concentration: 320000 nM
Compound 3: middle estimate off by 1.1-fold (0.03 log units), on the high side; low and high end bracket the measured number.
By their numbers in this assay, from the lowest: compounds 3, 2 and 1 (each within the scatter of the next).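

Compound 2 and compound 3 differ in one place only, which the earlier pair did not offer, so this change can now be read on its own. With 2-(nitrooxy)ethyl in place of nitrooxy on a saturated chain carbon, four bonds along the chain from an oxygen next to a carbonyl group, this assay gives a 1.1-fold lower number from compound 2 to compound 3 (0.05 log units; within the scatter), so lengthening the chain that carries the nitrooxy group has no discernible effect on this read-out over this span. Nothing at hand bears on what lies behind this result.

From the compounds shown here alone, it remains open whether a still longer chain ending in nitrooxy would stay within the scatter of compound 3. Going by these compounds, it is equally open whether replacing the nitrooxy end of this chain with a carboxylic acid or an amine would shift the value away from that of compound 2.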